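A few compounds are considered here, and "the series" means these few. Any claim that something is new, unique, unknown or untested is made for them only; others in the source may bear on it.

Compound 1, `Cc1ccc(CNc2ncnc3c2ncn3[C@@H]2O[C@H](CO)[C@@H](O)[C@H]2O)cc1`, carries a 4-methylphenyl group on the shared core. In a functional assay on G-361 cells (Homo sapiens) for antiproliferative activity, with a stated time of 72 h (on this read-out lower numbers stand for stronger inhibition and higher numbers for weaker inhibition), compound 1 gives "not determined" (no result reported), so no single number places it. Compound 2, `COc1cc(CNc2ncnc3c2ncn3[C@@H]2O[C@H](CO)[C@@H](O)[C@H]2O)cc(OC)c1O`, returned only a limit in this assay, > 166000 nM. That is the limit of > 166000 nM in this assay, at which 1 of the 2 values shown sits, a limit of the assay rather than a number. Compound 3, `OC[C@H]1O[C@@H](n2cnc3c(NCc4ccc(C(F)(F)F)cc4)ncnc32)[C@H](O)[C@@H]1O`, has not yet been tested; against compound 1 it shows (trifluoromethyl in place of methyl on an aromatic carbon), which read one bond further out is 4-methylphenyl to 4-(trifluoromethyl)phenyl. Within the data shown here, no pair of numbers shows what this swap does here, and with compound 1 itself without a number, no step beyond the usual scatter is expected in this assay in either direction. Compound 3 is expected at about 30000 nM in this assay, within a wide band from 5000 nM to 166000 nM.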

Compound 3, half-maximal inhibitory concentration: > 166000 nM
Compound 3 ended at the assay's limit (the forecaster's own chance of this, stated with the estimate: 40%); at least 5.5-fold (0.74 log units) between middle value and limit.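

No step can be read between compound 1, which has no reported result, and compound 3, which gives only a limit rather than a number: the limit of > 166000 nM in this assay, at which 2 of the 3 values shown sit.

The compounds shown leave open how methyl and trifluoromethyl compare in this assay, and where any of the three compounds would fall as an actual number.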